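The source may report more compounds than this note shows. Statements on the series, on what has been measured and on what is new or still open speak of the compounds shown alone.

Compound 3 `CCc1nnc(-c2ccc(-c3ccccc3)cc2)n1-c1cccc(Cl)c1C` gives 2200 nM in an assay on C6 glioma cells for displacement of a labelled ligand from sodium- and chloride-dependent glycine transporter 1 (Rattus norvegicus), read by scintillation counting, with stated times of 30 min and 10 min (a higher number here means a weaker inhibitor, a lower number a stronger inhibitor), the highest of the three numbers; compound 1 `CCc1nnc(-c2ccc(-c3ccccc3)cc2)n1-c1cccc(N)c1C` gives 320 nM and compound 2 `CCc1nnc(-c2ccc(-c3ccccc3)cc2)n1-c1cccc(CO)c1C` gives 250 nM. Compound 4 `CCc1nnc(-c2ccc(-c3ccccc3)cc2)n1-c1cccc(C(=O)OC)c1C` carries methoxycarbonyl in place of chloro on an aromatic carbon. Among the compounds with values here, no step exchanges chloro for methoxycarbonyl directly; the nearest are a 6.9-fold higher number from compound 1 to compound 3 (0.84 log units; beyond the scatter) and an 8.8-fold higher number from compound 2 to compound 3 (0.94 log units; beyond the scatter), both putting chloro in place of a substituent bearing heteroatoms, and both modest worsenings. Reading them backwards, a substituent with two acceptors in place of chloro is expected to lower the number by a modest amount, roughly a 4.9-fold lower number from compound 3 to compound 4 (0.69 log units; beyond the scatter), because compound 1 gives 320 nM and compound 2 gives 250 nM. Compound 4 is therefore estimated at 450 nM, with a range from 150 nM to 1400 nM.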

Compound 4, half-maximal inhibitory concentration: 5100 nM
Beside the measured number, compound 4's estimate is 11-fold (1.05 log units) below it, and the stated range ends below it.
By their numbers in this assay, from the lowest: compounds 2 and 1 (each within the scatter of the next); then compound 3; then compound 4.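

In this assay, the two hydrogen-bond acceptors of methoxycarbonyl do not bring back the level of the amino and hydroxymethyl compounds, and the number rises even past that of chloro (a 2.3-fold higher number from compound 3 to compound 4 (0.37 log units; beyond the scatter)). The gaps to hydroxymethyl (a 20-fold higher number from compound 2 to compound 4 (1.31 log units; beyond the scatter)) and amino (a 16-fold higher number from compound 1 to compound 4 (1.20 log units; beyond the scatter)) are large, so at this position, ortho to a methyl group, acceptor count alone does not track the number. No accompanying measurement accounts for this change.

Still open, as far as these compounds go, is whether a carboxylic acid or a primary amide here would return to the numbers of compound 1 and compound 2.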